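Moving the amide along the chain: compound 2 to compound 4

The compounds below may be only part of what the source reports. "The series", "measured", "known", "first", "only" and "open" are said of these compounds alone.

Measured so far:
Compound 1 `CCCC(=O)OCSc1ccccc1C(=O)NC1(C(N)=O)CCCC1`: in an ADME assay on CEM-SS cells (Homo sapiens) for cytotoxicity, read by XTT assay, with a stated time of 6 days (on this read-out lower numbers stand for higher toxicity in this test and higher numbers for lower toxicity in this test), compound 1 gives > 100 uM, which is a limit of the assay and not a number.
Compound 2 `CCCC(=O)OCSc1ccccc1C(=O)NCCCCCC(N)=O`: in this assay compound 2 gives 16.3 uM.
Compound 3 `CCCC(=O)OCSc1ccccc1C(=O)N[C@H]1CCC[C@@H]1C(N)=O`: in this assay compound 3 gives 31.2 uM; 43.3 uM (2 entries).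

Among the compounds with values here, compound 2 therefore holds the only single number in this assay; one further entry is a limit, and one compound is represented by repeated entries, (the several entries of compound 3 in this assay, 31.2 uM; 43.3 uM (2 entries)), which show how much repeats of this kind can differ from each other. Within the data shown here, only one step between measured compounds is available, an at least 6.1-fold lower number from compound 1 to compound 2 (0.78 log units; beyond the scatter), and it shows that a change of the group on the amide-type nitrogen can move the read-out well beyond the scatter.

Compound 4 `CCCCCNC(=O)CNC(=O)c1ccccc1SCOC(=O)CCC` differs from compound 2 by pentylcarbamoyl in place of 4-carbamoylbutyl on a saturated chain carbon bound to an amide-type nitrogen. Both groups are open chains of nearly the same size carrying one amide, so the measured step, which swapped a ring for a chain, is a loose guide here. A step no larger than the scatter, or a modest shift toward a higher number, is expected. Compound 4 is estimated at 25 uM, with a plausible range from 8 uM to 80 uM. The expected step is a 1.5-fold higher number from compound 2 to compound 4 (0.19 log units; within the scatter).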

Compound 4, half-maximal toxic concentration: 24.8 uM
The estimate for compound 4 lay 1.0-fold (0.00 log units) above the measured number; the measured number falls inside the stated range.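

In this assay, within the data shown here, pentylcarbamoyl in place of 4-carbamoylbutyl on a saturated chain carbon bound to an amide-type nitrogen gives a 1.5-fold higher number from compound 2 to compound 4 (0.18 log units; within the scatter), so at this place one open chain carrying an amide can be exchanged for another with no step that stands out from the scatter. Among these compounds, the only earlier step, an at least 6.1-fold lower number from compound 1 to compound 2 (0.78 log units; beyond the scatter), exchanged a ring for a chain and lay beyond the scatter, whereas the new step shows that the amide can be moved along an open chain, with the count of one hydrogen-bond donor and one hydrogen-bond acceptor kept, and the read-out does not separate the two compounds. The gap between compound 2 and compound 4 is of the kind that repeats of a single compound also show: the several entries of compound 3 in this assay, 31.2 uM; 43.3 uM (2 entries).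

The compounds shown leave open whether a carboxylic acid or an amine in place of the amide at this place would keep the read-out in the same range. They also do not tell whether a longer chain than pentylcarbamoyl would leave the read-out within the scatter of compound 4.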